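The source may report more compounds than this note shows. Statements on the series, on what has been measured and on what is new or still open speak of the compounds shown alone.

Measured so far in a physicochemical assay for solubility, in phosphate buffer, at pH 7.4; a lower number here means a less soluble compound, a higher number a more soluble compound:
- compound 1 `OCC1CCN(c2nccnc2OC2CN(c3ccc4ccccc4n3)C2)C1`: 167000 nM
- compound 2 `N#CC1CCN(c2nccnc2OC2CN(c3ccc4ccccc4n3)C2)CC1`: 66000 nM

Compound 2 holds the lower of these two numbers. Compound 3 `NC(=O)C1CCN(c2nccnc2OC2CN(c3ccc4ccccc4n3)C2)CC1` keeps the shared core and alters one group, with carbamoyl in place of cyano on a saturated ring carbon. Among the compounds with values here, no measurement yet compares these two groups directly. The nearest evidence is a single modest step, a 2.5-fold lower number from compound 1 to compound 2 (0.40 log units; beyond the scatter), which replaced 3-(hydroxymethyl)pyrrolidin-1-yl with 4-cyanopiperidin-1-yl. That is a different change, so it is only a loose guide to size, and it gives a weak hint on direction. Removing the cyano group may recover a little of what that step lost, but no more than that. The expected change is small and upward: a 1.5-fold higher number from compound 2 to compound 3 (0.18 log units; within the scatter). For compound 3, the estimated value in this assay is 100000 nM, with an expected range of 35000 nM to 250000 nM.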

Compound 3, solubility: 14000 nM
Estimate against measurement, compound 3: 7.1-fold (0.85 log units) above; the measured number lies below the stated range.
By their numbers in this assay, from the lowest: compound 3; then compound 2; then compound 1.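

In this assay, the group on this saturated ring carbon proves able to shift the number clearly: carbamoyl in place of cyano gives a 4.7-fold lower number from compound 2 to compound 3 (0.67 log units; beyond the scatter) and so continues downward rather than recovering the earlier loss. Carbamoyl has 1 hydrogen-bond donor and cyano has 0, so in this pair, adding a donor did not raise the number, and 4-carbamoylpiperidin-1-yl in place of 3-(hydroxymethyl)pyrrolidin-1-yl gives a 12-fold lower number from compound 1 to compound 3 (1.08 log units; beyond the scatter) as the widest step in the set. No supporting measurement explains why the number falls with this change.

On these data alone, it remains open how a carboxylic acid, an amine or a hydroxymethyl group on the same piperidine carbon would compare. Also open, as far as these compounds go, is whether placing methyl groups on the amide nitrogen would change the result for carbamoyl.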